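The source may hold more compounds than are shown below. What is called first, only, known or untested is meant among the compounds shown, and "the series" means these compounds.

Working notes on the series

Compound 1 `O=C(CCCCl)Nc1ccc(I)cc1` and compound 3 `C=CC(=O)Nc1ccc(I)cc1` share one core; compound 2 `CCCCC(O)c1cccc(NC(=O)CCCCl)c1` and compound 4 `C=CC(=O)Nc1cccc(C(O)CCCC)c1` share another, and the difference between the two cores is not broken down here. In a functional assay on M21 cells (Homo sapiens) for antiproliferative activity, with a stated time of 48 h (on this read-out higher numbers stand for weaker inhibition and lower numbers for stronger inhibition), compound 1 gives only a limit, > 100000 nM. Compound 2 likewise gives only a limit in this assay, > 100000 nM. Compound 3 gives 11000 nM in this assay, so the change vinyl in place of 3-chloropropyl on a carbonyl carbon made a step of an at least 9.0-fold lower number from compound 1 to compound 3 (0.95 log units; beyond the scatter); as the limit of > 100000 nM in this assay, at which 2 of the 3 values shown sit, is where compound 1 sits, the true size of that step is open. Compound 4 carries the same change, (vinyl in place of 3-chloropropyl on a carbonyl carbon), on the core of compound 2. With compound 2 also at a limit, the step to compound 4 is expected to be about an at least 5.0-fold lower number from compound 2 to compound 4 (0.69 log units; beyond the scatter), resting on an at least 9.0-fold lower number from compound 1 to compound 3 (0.95 log units; beyond the scatter). The expected value for compound 4 in this assay is 20000 nM, within 5000 nM to 100000 nM.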

Compound 4, half-maximal inhibitory concentration: 98000 nM
For compound 4 the middle estimate is 4.9-fold (0.69 log units) below the measured one, and the stated range covers the measured number.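

Carried to the second core, vinyl in place of 3-chloropropyl on a carbonyl carbon gives in this assay a step of an at least 1.0-fold lower number from compound 2 to compound 4 (0.00 log units; that floor lies within the scatter). Compound 2 gives only a limit, > 100000 nM. This does not conflict with the earlier step, but it does not show that the change carries over with the same size, or with a size beyond the scatter: the same change on two cores in this assay, an at least 9.0-fold lower number (0.95 log units; beyond the scatter) from compound 1 to compound 3 and an at least 1.0-fold lower number (0.00 log units; that floor lies within the scatter) from compound 2 to compound 4; the limit leaves it open whether they differ

Open, from the compounds shown here alone, is whether the lower number on the first core needs the vinyl group itself, or would also appear with another group on the carbonyl carbon, such as an ethyl or a longer chloroalkyl chain. The true positions of compound 1 and compound 2 also stay open: the limit of > 100000 nM in this assay, at which 2 of the 4 values shown sit.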